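Fluoro in place of methyl: from compound 1 to compound 3

The source may report more compounds than this note shows. Statements on the series, on what has been measured and on what is new or still open speak of the compounds shown alone.

In a functional assay on cells for agonist activity at Glucose-dependent insulinotropic receptor (Homo sapiens), read by a luciferase reporter, with a stated time of 4 h (on this read-out lower numbers stand for smaller maximal responses and higher numbers for larger maximal responses), compound 1 `Cc1cnc(N2CCC(c3coc4c(N5CCc6cc(S(C)(=O)=O)ccc65)ncnc34)CC2)nc1` gives 159%, the higher of the two measured numbers. Compound 2 `CC(C)(C)OC(=O)N1CCC(c2c[nH]c3c(Nc4ccc(S(C)(=O)=O)cc4F)ncnc23)CC1` gives 9% in this assay, far below compound 1 and beyond the scatter; the two differ in several places at once, so no single change links them. Compound 3 `CS(=O)(=O)c1ccc2c(c1)CCN2c1ncnc2c(C3CCN(c4ncc(F)cn4)CC3)coc12` differs from compound 1 by fluoro in place of methyl on an aromatic carbon. For such a change a step of no more than the scatter is expected, with no clear direction. Compound 3 is expected to reach about 150%, within 115% to 185%. The estimated step of a number 9 percentage points lower from compound 1 to compound 3 (within the scatter) would stay inside the scatter.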

Compound 3, largest response reached (Emax), in percent of the reference or control that the assay uses: 229%
The estimate for compound 3 lay 79 percentage points below the measured number; the whole stated range lies below it.
By their numbers in this assay, from the lowest: compound 2; then compound 1; then compound 3.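

The exchange of methyl for fluoro on this aromatic carbon, para to a large group, gives a number 70 percentage points higher from compound 1 to compound 3 (beyond the scatter) in this assay. The maximal response at this position is therefore sensitive to a one-atom change, which compound 2 could not show, since it differs from compound 1 in several places at once. Nothing in the data shown accounts for this step.

Still open, as far as these compounds go, is how far the response follows the group at this position, for example with chloro, nitrile or methoxy. From the compounds shown here alone, whether the step carries over to other substituents on the shared core also remains open.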